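The source may hold more compounds than are shown below. What is called first, only, known or untested is meant among the compounds shown, and "the series" means these compounds.

Three compounds were tested in an assay on HL-60 cells for agonist activity at vitamin D3 receptor (Homo sapiens), read by microscopy, with a stated time of 96 h; a lower number here means that less compound is needed, a higher number that more compound is needed for the effect. Compound 1 `CCN(CC)CCCNC(=O)c1ccc(C(CC)(CC)c2ccc(OCC(=O)C(C)(C)C)c(C)c2)n1CC` gives 22 nM. Compound 2 `CCN(CC)CCCNC(=O)c1ccc(C(CC)(CC)c2ccc(OCC(O)C(C)(C)C)c(C)c2)n1CC` carries a 1-hydroxy-2,2-dimethylpropyl group where compound 1 carries a (tert-butyl)carbonyl group. In this assay compound 2 gives 66 nM; the step is a 3.0-fold higher number from compound 1 to compound 2 (0.48 log units; beyond the scatter). Compound 3 `CCOC(=O)c1ccc(OC(=O)c2ccc(C(CC)(CC)c3ccc(OCC(=O)C(C)(C)C)c(C)c3)n2CC)cc1` has a 4-(ethoxycarbonyl)phenoxy group in place of the (3-(diethylamino)propyl)amino group of compound 1. In this assay compound 3 gives 45600 nM, and that step is a 2100-fold higher number from compound 1 to compound 3 (3.32 log units; beyond the scatter). Among these three numbers compound 2 stands second highest, close to compound 1 and far from compound 3.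

Compound 4 `CCn1c(C(=O)Nc2cccc(C(F)(F)F)c2)ccc1C(CC)(CC)c1ccc(OCC(O)C(C)(C)C)c(C)c1` has not yet been measured. It differs from compound 2 at one place: 3-(trifluoromethyl)phenyl in place of 3-(diethylamino)propyl on an amide-type nitrogen. So the 3-(diethylamino)propyl group leaves and a 3-(trifluoromethyl)phenyl group enters, while the amide-type nitrogen itself remains.

Within the data shown here, the only measured step touching this part of the molecule is the one from compound 1 to compound 3, which removed the whole (3-(diethylamino)propyl)amino group and was very large. Compound 4 removes the same 3-(diethylamino)propyl chain but keeps the amide-type nitrogen, so a sizeable rise in the number is expected, though not as large as that one step. The expected step is a 30-fold higher number from compound 2 to compound 4 (1.48 log units; beyond the scatter). Compound 4 is therefore estimated at 2000 nM, within a range from 300 nM to 15000 nM.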

Compound 4, half-maximal effective concentration: > 50000 nM
Compound 4: no number, only a limit (the forecaster's own chance of this, stated with the estimate: 10%); middle value at least 25-fold (1.39 log units) from the limit.
By their numbers in this assay, from the lowest: compound 1; then compound 2; then compound 3. At a limit, above all of these: compound 4.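

In this assay compound 4 gives a limit rather than a number: the limit of > 50000 nM in this assay, at which 1 of the 4 values shown sits.

Even so, exchanging 3-(diethylamino)propyl for 3-(trifluoromethyl)phenyl gives an at least 750-fold higher number from compound 2 to compound 4 (2.87 log units; beyond the scatter), and this is the first step shown in which the amide-type nitrogen stays and only the group it carries changes. The earlier change, a 2100-fold higher number from compound 1 to compound 3 (3.32 log units; beyond the scatter), removed that nitrogen together with the chain, so it could not show whether keeping the nitrogen would be enough. The new step shows that, in this pair, keeping the nitrogen does not hold the number low once 3-(trifluoromethyl)phenyl takes the place of 3-(diethylamino)propyl.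

The compounds shown leave open whether the rise comes from losing 3-(diethylamino)propyl or from gaining 3-(trifluoromethyl)phenyl, since this one change does both at once. A plain propyl chain or an unsubstituted phenyl on the same nitrogen would help separate these two parts, and a longer chain ending in the same diethylamino group would show how much the chain length matters.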